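This account rests on a few compounds, and the source may have more. Where it says the series, first, only, none or still open, it means among the compounds named here.

The measured compounds in an assay on NIH3T3 cells for inhibition of Sonic hedgehog protein (Mus musculus), read by a luciferase reporter, with a stated time of 48 h; on this read-out higher numbers stand for weaker inhibition and lower numbers for stronger inhibition:
compound 1 `Cc1ccccc1C(=O)Nc1ccc(Nc2ncc(C)c(-c3ccc(OC(F)(F)F)cc3)n2)cc1`, 42.1 nM
compound 2 `Cc1cnc(Nc2ccc(C(=O)Nc3c(C)cccc3C)cc2)nc1-c1ccc(OC(F)(F)F)cc1`, 1.3 nM
compound 3 `Cc1ccccc1NC(=O)c1ccc(Nc2ncc(C)c(-c3ccc(OC(F)(F)F)cc3)n2)cc1`, 1 nM

Compound 3 gives a number far below that of compound 1 and indistinguishable from that of compound 2. Against compound 1 the gap is a 42-fold lower number from compound 1 to compound 3 (1.62 log units; beyond the scatter), while the step of a 1.3-fold lower number from compound 2 to compound 3 (0.11 log units; within the scatter) stays within the scatter, so compound 2 and compound 3 cannot be set apart on these numbers. Compound 4 `Cc1ccc(-c2cnn(C)c2)cc1NC(=O)c1ccc(Nc2ncc(C)c(-c3ccc(OC(F)(F)F)cc3)n2)cc1` keeps the core of compound 3 and differs from it by 1-methyl-1H-pyrazol-4-yl in place of hydrogen on an aromatic carbon. Going by the values given here, no measured step touches that position. Among the compounds with values here, the only change on that ring among the measured compounds is a 1.3-fold lower number from compound 2 to compound 3 (0.11 log units; within the scatter), which stayed within the scatter, and the large steps of a 32-fold lower number from compound 1 to compound 2 (1.51 log units; beyond the scatter) and a 42-fold lower number from compound 1 to compound 3 (1.62 log units; beyond the scatter) concern the exchange of the ((2-methylphenyl)carbonyl)amino group for a carbamoyl group, a feature compound 4 shares with compound 3 unchanged. There is therefore nothing in the data to foretell a large shift either way, and the expected step of a 1.5-fold higher number from compound 3 to compound 4 (0.18 log units; within the scatter) lies within the scatter. Compound 4 is thus estimated at 1.5 nM in this assay, with a range from 0.4 nM to 6 nM.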

Compound 4, half-maximal inhibitory concentration: 1.2 nM
Compound 4: middle estimate off by 1.3-fold (0.10 log units), on the high side; low and high end bracket the measured number.
By their numbers in this assay, from the lowest: compounds 3, 4 and 2 (each within the scatter of the next); then compound 1.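

The step of a 1.2-fold higher number from compound 3 to compound 4 (0.08 log units; within the scatter) in this assay shows that this aromatic carbon, para to a methyl group and meta to a large group, can carry 1-methyl-1H-pyrazol-4-yl without the number leaving the scatter. The earlier compounds shown here all held hydrogen here, so they gave no sign of what a substituent at this carbon would do; compound 4 now shows that a group of 6 heavy atoms, with one five-membered aromatic ring and 2 hydrogen-bond acceptors, leaves the reading where compound 3 stands. Nothing accompanying this result accounts for the lack of a shift, so it stands as an observation without an explanation.

With a single substituent shown at this carbon, the result cannot be extended to other groups, and a carboxylic acid, a primary amine or a longer chain ending in a morpholine could behave differently there. Going by these compounds, it also remains open whether 1-methyl-1H-pyrazol-4-yl would leave the number similarly unmoved on the ring of compound 2, which carries a second methyl group.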